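A few compounds are considered here, and "the series" means these few. Any claim that something is new, unique, unknown or untested is made for them only; others in the source may bear on it.

Compound 1 `COc1cc(NC(=O)NOCCCCCC(=O)NO)c2ncccc2c1` gives 900 nM in a functional assay on CAL-27 cells (Homo sapiens) for antiproliferative activity, read by MTT assay, with a stated time of 72 h (a lower number here means a stronger inhibitor, a higher number a weaker inhibitor), and compound 2 `COc1cc(NC(=O)NOCCCCCC(=O)NO)c2nccc(C)c2c1` gives 600 nM in the same test. These two compounds differ by methyl in place of hydrogen on an aromatic carbon, and the result is a 1.5-fold lower number from compound 1 to compound 2 (0.18 log units; within the scatter) of this pair. Compound 2 therefore stands level with compound 1, and the two values cannot be told apart.

Compound 3 `COc1cc(NC(=O)NOCCCCCC(=O)NO)c2nc(OC)cc(C)c2c1` takes compound 2 one change further: methoxy in place of hydrogen on an aromatic carbon (methoxy in place of hydrogen on an aromatic carbon, next to the ring nitrogen). Among the compounds with values here, no measured step involves a methoxy group or this place on the shared core, so the evidence is thin. Within the data shown here, the only guide is the small methyl step on another carbon of compound 2, a 1.5-fold lower number from compound 1 to compound 2 (0.18 log units; within the scatter) here, and it gives no reason to expect a large move. No direction can be argued from it, and no step beyond the scatter is expected in this assay. The estimate amounts to an expected 1.2-fold lower number from compound 2 to compound 3 (0.08 log units; within the scatter) in this test. For compound 3 the estimated value is 500 nM, with an expected range from 180 nM to 1400 nM in this test.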

Compound 3, half-maximal inhibitory concentration: 1000 nM
Compound 3: the middle estimate sits 2.0-fold (0.30 log units) below what was measured, within the range that was stated.
By their numbers in this assay, from the lowest: compounds 2, 1 and 3 (each within the scatter of the next).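

In this assay, methoxy in place of hydrogen on the aromatic carbon next to the ring nitrogen gives a 1.7-fold higher number from compound 2 to compound 3 (0.22 log units; within the scatter) and so leaves the number within the scatter. This extends the picture beyond the methyl step, a 1.5-fold lower number from compound 1 to compound 2 (0.18 log units; within the scatter) on another aromatic carbon: a group of 2 heavy atoms with 1 hydrogen-bond acceptor can also stand on this ring, here at a second place, without a step that can be told from the scatter. No measurement available here bears on why this step is so small or on what the methoxy group does at this place.

The compounds shown leave open whether larger or differently built groups would also stay within the scatter: an amine, a carboxylic acid or a longer chain such as butoxy on the same carbon could still give a clear step in either direction. They also leave open whether methoxy at this place would read the same on the core of compound 1, which carries hydrogen instead of the methyl group of compound 2.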